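A new ring group on the sulfur

The source may hold more compounds than are shown below. What is called first, only, known or untested is meant among the compounds shown, and "the series" means these compounds.

Compound 1 (`COc1ccc(CN(C(=O)CSc2ccccn2)c2cc(OC)c(OC)c(OC)c2)cc1`) gives 2410 nM
Compound 2 (`COc1ccc(CN(C(=O)CSC2=CN=NC2C)c2cc(OC)c(OC)c(OC)c2)cc1`) gives 2960 nM
Compound 3 (`COc1ccc(CN(C(=O)CSc2nnnn2C)c2cc(OC)c(OC)c(OC)c2)cc1`) gives 2490 nM

All three were tested in a functional assay on MGC-803 cells (Homo sapiens) for antiproliferative activity, read by MTT assay, with a stated time of 48 h; a higher number here means a weaker inhibitor, a lower number a stronger inhibitor. Compound 3 (2490 nM) lies within the scatter of both compound 1 and compound 2. Compound 4 (`COc1ccc(CN(C(=O)CSc2nc3ccccc3o2)c2cc(OC)c(OC)c(OC)c2)cc1`) differs from compound 3 in one place (1,3-benzoxazol-2-yl in place of 1-methyl-1H-tetrazol-5-yl on a sulfur), with 1,3-benzoxazol-2-yl in place of 1-methyl-1H-tetrazol-5-yl on a sulfur. Three measured swaps at this sulfur bear on it (a 1.0-fold higher number from compound 1 to compound 3 (0.01 log units; within the scatter), a 1.2-fold higher number from compound 1 to compound 2 (0.09 log units; within the scatter), a 1.2-fold lower number from compound 2 to compound 3 (0.08 log units; within the scatter)), and all stayed within the scatter. None of those groups carries a second ring, so this is an extrapolation. No change beyond the scatter is expected in this assay, in either direction, and the estimated step is small (a 1.0-fold lower number from compound 3 to compound 4 (0.02 log units; within the scatter)). Compound 4 is expected near 2400 nM (estimated range 900 nM to 6000 nM).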

Compound 4, half-maximal inhibitory concentration: 450 nM
For compound 4 the middle estimate is 5.3-fold (0.73 log units) above the measured one; the whole stated range lies above it.
By their numbers in this assay, from the lowest: compound 4; then compounds 1, 3 and 2 (each within the scatter of the next).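

In this assay, this sulfur position proves sensitive to the group it carries, as 1,3-benzoxazol-2-yl stands apart from all three earlier groups (a 5.5-fold lower number from compound 3 to compound 4 (0.74 log units; beyond the scatter)) and (a 5.4-fold lower number from compound 1 to compound 4 (0.73 log units; beyond the scatter)) and (a 6.6-fold lower number from compound 2 to compound 4 (0.82 log units; beyond the scatter)). The earlier swaps all stayed within the scatter, and this is the first group shown with a second ring, a six-membered aromatic ring of carbon only. Nothing measured here explains the step.

As far as these compounds go, compound 4 also brings a ring oxygen, so it cannot show which change matters. 1,3-Oxazol-2-yl, with the oxygen but no second ring, and 1,3-benzothiazol-2-yl, with the second ring and sulfur for oxygen, remain open.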